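Bromo and sulfonyl changes on a shared indole-indazole amine core

This account rests on a few compounds, and the source may have more. Where it says the series, first, only, none or still open, it means among the compounds named here.

Measured compounds:
Compound 1 `CN(C(=O)c1ccccc1)c1ccc2[nH]c(-c3n[nH]c4ccccc34)cc2n1` gives 12500 nM in a functional assay on SMMC-7721 cells (Homo sapiens) for antiproliferative activity, read by MTT assay, with a stated time of 72 h; on this read-out lower numbers stand for stronger inhibition and higher numbers for weaker inhibition.
Compound 2 `CN(C(=O)c1ccc(Br)cc1)c1ccc2[nH]c(-c3n[nH]c4ccccc34)cc2n1` gives 3460 nM in this assay.
Compound 3 `Cc1ccc(S(=O)(=O)N(C)c2ccc3[nH]c(-c4n[nH]c5ccccc45)cc3n2)cc1` gives 16300 nM in this assay.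

Among these three numbers compound 1 stands second highest; its nearest neighbour is compound 3, with a difference that lies within the scatter, and its furthest is compound 2, which lies beyond it. The step from compound 1 to compound 4 `CN(c1ccc2[nH]c(-c3n[nH]c4ccccc34)cc2n1)S(=O)(=O)c1ccc(Br)cc1` changes the substituent on a nitrogen on an aromatic ring: (4-bromophenyl)sulfonyl in place of benzoyl on a nitrogen on an aromatic ring.

For the measured compounds named here, two measured steps bear on this change. Adding bromo to the aromatic carbon gave a 3.6-fold lower number from compound 1 to compound 2 (0.56 log units; beyond the scatter), a modest gain. Replacing benzoyl with (4-methylphenyl)sulfonyl gave a 1.3-fold higher number from compound 1 to compound 3 (0.12 log units; within the scatter), which is within the scatter. Since compound 4 combines a sulfonyl linker with a bromo substituent, the bromo contribution seen in compound 2 is expected to carry over while the sulfonyl change seen in compound 3 is expected to add little. Compound 4 is therefore expected to show a 2.8-fold lower number from compound 1 to compound 4 (0.44 log units; beyond the scatter), a modest lowering. Compound 4 is estimated at 4500 nM, with a range from 1800 nM to 12000 nM.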

Compound 4, half-maximal inhibitory concentration: 11500 nM
The estimate for compound 4 lay 2.6-fold (0.41 log units) below the measured number, and the stated range covers the measured number.
By their numbers in this assay, from the lowest: compound 2; then compounds 4, 1 and 3 (each within the scatter of the next).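

In this assay, the gain from bromo seen with the benzoyl group did not carry over to the sulfonyl linker on this nitrogen: (4-bromophenyl)sulfonyl in place of benzoyl gave a 1.1-fold lower number from compound 1 to compound 4 (0.04 log units; within the scatter), and bromo in place of methyl gave a 1.4-fold lower number from compound 3 to compound 4 (0.15 log units; within the scatter), both within the scatter. With the bromo held fixed, the linker alone made a difference beyond the scatter, as (4-bromophenyl)sulfonyl in place of (4-bromophenyl)carbonyl gave a 3.3-fold higher number from compound 2 to compound 4 (0.52 log units; beyond the scatter), so among these four compounds the two changes do not add up and only the carbonyl-linked compound 2 stands apart. Nothing available explains why the effect of bromo depends on the linker.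

The compounds shown leave open how a sulfonyl group with an unsubstituted phenyl ring compares, since bromo is set against methyl on that linker and against hydrogen only on the carbonyl one. They also leave open whether the dependence on the linker extends to other groups in place of bromo, such as chloro, methoxy or an amine, on either linker.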